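The source may report more compounds than this note shows. Statements on the series, on what has been measured and on what is new or still open speak of the compounds shown alone.

Going by the values given here, compound 3 `COc1cccc(/C=C/C(=O)Nc2ccc3ncnc(Nc4cccc(Cl)c4)c3c2)c1` gives the lowest of the three numbers so far: in a functional assay on A549 cells (Homo sapiens) for antiproliferative activity, read by MTT assay, with a stated time of 48 h (on this read-out lower numbers stand for stronger inhibition and higher numbers for weaker inhibition), compound 3 gives 2.58 ug/mL. Compound 2 `O=C(/C=C/c1ccccc1Cl)Nc1ccc2ncnc(Nc3cccc(Cl)c3)c2c1` gives 4.58 ug/mL in this assay, which lies within the scatter of compound 3. Compound 1 `O=C(/C=C/c1ccc(Cl)cc1)Nc1ccc2ncnc(Nc3cccc(Cl)c3)c2c1` gives 12.4 ug/mL, and the gap to compound 3 is beyond the scatter.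

Compound 4 `Cc1ccc(/C=C/C(=O)Nc2ccc3ncnc(Nc4cccc(Cl)c4)c3c2)cc1` differs from compound 3 in one place: 4-methylphenyl in place of 3-methoxyphenyl on a double-bonded chain carbon bound to a double-bonded chain carbon. All three measured steps bear on this, since each swaps the group at the same place: a 2.7-fold lower number from compound 1 to compound 2 (0.43 log units; beyond the scatter), a 4.8-fold lower number from compound 1 to compound 3 (0.68 log units; beyond the scatter) and a 1.8-fold lower number from compound 2 to compound 3 (0.25 log units; within the scatter). Of the measured compounds, compound 1, with a 4-chlorophenyl, carries the group most like the 4-methylphenyl that enters here, and compound 1 gives the highest number of the three. The 3-methoxyphenyl that leaves belongs to the compound with the lowest number.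

The expectation is therefore a modest rise in this assay, a 2.3-fold higher number from compound 3 to compound 4 (0.37 log units; beyond the scatter), landing between the numbers of compound 3 and compound 1. Compound 4 is estimated at 6 ug/mL, with a likely range from 2.5 ug/mL to 14 ug/mL.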

Compound 4, half-maximal inhibitory concentration: 6.03 ug/mL
Beside the measured number, compound 4's estimate is 1.0-fold (0.00 log units) below it, within the range that was stated.
By their numbers in this assay, from the lowest: compounds 3, 2 and 4 (each within the scatter of the next, the first and the last beyond it); then compound 1.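

Going by these compounds alone, the step of a 2.1-fold lower number from compound 1 to compound 4 (0.31 log units; beyond the scatter) is the first that keeps the substituent at the same place on the ring and changes only the substituent itself, so methyl and chloro on an aromatic carbon can be told apart here, not only different substitution patterns. The step of a 2.3-fold higher number from compound 3 to compound 4 (0.37 log units; beyond the scatter) shows that the 3-methoxyphenyl of compound 3 keeps a clear edge over this 4-methylphenyl, whereas the step of a 1.3-fold higher number from compound 2 to compound 4 (0.12 log units; within the scatter) leaves compound 2 and compound 4 inseparable, so a group that carries its substituent at the ring's 4 position does not always end up as far from compound 3 as compound 1 does. Nothing available here accounts for these differences.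

Because the methoxy and methyl groups also sit at different ring places in compound 3 and compound 4, these compounds cannot show whether the group or its place matters more, and a 4-methoxyphenyl or a 3-methylphenyl at this position would separate the two. Also open, from the compounds shown here alone, is how a plain phenyl, or a ring bearing an amine or a carboxylic acid, would behave at the same position.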